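From 2-chlorobenzyl to 2,4-dichlorobenzyl

The compounds below may be only part of what the source reports. "The series", "measured", "known", "first", "only" and "open" are said of these compounds alone.

In a functional assay on A549 cells (Homo sapiens) for antiproliferative activity, read by MTT assay, with a stated time of 48 h (on this read-out lower numbers stand for stronger inhibition and higher numbers for weaker inhibition), compound 1 (`O=[N+]([O-])c1cc(C(F)(F)F)cc([N+](=O)[O-])c1Oc1c(Cl)cc(Cl)cc1/C=N\OCc1ccccc1F`) gives 1230 nM and compound 2 (`O=[N+]([O-])c1cc(C(F)(F)F)cc([N+](=O)[O-])c1Oc1c(Cl)cc(Cl)cc1/C=N/OCc1ccccc1Cl`) gives 2160 nM, two values within the scatter of each other. Compound 3 (`O=[N+]([O-])c1cc(C(F)(F)F)cc([N+](=O)[O-])c1Oc1c(Cl)cc(Cl)cc1/C=N/OCc1ccc(Cl)cc1Cl`) has chloro in place of hydrogen on an aromatic carbon, meta to a chloro group and para to a large group: chloro in place of hydrogen on an aromatic carbon. Within the data shown here, the only measured step that bears on this is a 1.8-fold higher number from compound 1 to compound 2 (0.24 log units; within the scatter), a different change on the same kind of ring, and it stays within the scatter. No step beyond the scatter is therefore expected in this assay. The estimated step is a 1.1-fold lower number from compound 2 to compound 3 (0.03 log units; within the scatter). For compound 3, the expected value is 2000 nM, with an estimated range of 800 nM to 5000 nM.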

Compound 3, half-maximal inhibitory concentration: 1420 nM
Compound 3: the middle estimate sits 1.4-fold (0.15 log units) above what was measured; measured number inside the range.
By their numbers in this assay, from the lowest: compounds 1, 3 and 2 (each within the scatter of the next).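

In this assay, chloro in place of hydrogen on this aromatic carbon, para to a large group, gives a 1.5-fold lower number from compound 2 to compound 3 (0.18 log units; within the scatter) and thus no step beyond the scatter at this position. The wider change from the fluorine-bearing group of compound 1 to the 2,4-dichlorobenzyl group gives a 1.2-fold higher number from compound 1 to compound 3 (0.06 log units; within the scatter) and so also stays within the scatter. No measurement here explains these small steps.

Still open, as far as these compounds go, is whether an amine or a carboxylic acid at this position would give a step beyond the scatter. From the compounds shown here alone, a longer chain on the same ring is equally open.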